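A methoxy group replaces a methyl on the aryl amide

A few compounds are considered here, and "the series" means these few. Any claim that something is new, unique, unknown or untested is made for them only; others in the source may bear on it.

In a functional assay on T47D cells (Homo sapiens) for inhibition, read by CCK-8 assay, with a stated time of 72 h, tested at 1 uM (on this read-out higher numbers stand for more inhibition of growth at the one concentration tested and lower numbers for less inhibition of growth), compound 3 `Cc1ccc(NC(=O)C2(C(=O)Nc3ccc(Nc4ncc5cc(C(=O)N(C)C)n(C6CCCC6)c5n4)cc3)CC2)cc1` gives 47.9%. This lies within the scatter of compound 1 `Cc1cccc(NC(=O)C2(C(=O)Nc3ccc(Nc4ncc5cc(C(=O)N(C)C)n(C6CCCC6)c5n4)cc3)CC2)c1` at 45.7%, and well short of compound 2 `CN(C)C(=O)c1cc2cnc(Nc3ccc(NC(=O)C4(C(=O)Nc5cccc(O)c5)CC4)cc3)nc2n1C1CCCC1` at 80.7%. Compound 4 `COc1cccc(NC(=O)C2(C(=O)Nc3ccc(Nc4ncc5cc(C(=O)N(C)C)n(C6CCCC6)c5n4)cc3)CC2)c1` carries 3-methoxyphenyl in place of 4-methylphenyl on an amide-type nitrogen. Among the compounds with values here, two measured steps bear on this. Having 4-methylphenyl in place of 3-methylphenyl gave a number 2.2 percentage points higher from compound 1 to compound 3 (within the scatter), so the shift of the group alone is expected to count for little. Hydroxy in place of methyl gave a number 35 percentage points higher from compound 1 to compound 2 (beyond the scatter), a large step, but methoxy is not hydroxy, and no measurement yet shows how far that gain carries over. A modest rise is therefore expected, an estimated a number 8.1 percentage points higher from compound 3 to compound 4 (within the scatter). For compound 4 the estimate is 56%, with an expected range from 40% to 76%.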

Compound 4, percent growth inhibition at one concentration: 56.3%
Compound 4: the middle estimate sits 0.3 percentage points below what was measured; measured number inside the range.
By their numbers in this assay, from the lowest: compounds 1, 3 and 4 (each within the scatter of the next, the first and the last beyond it); then compound 2.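

In this assay, putting a methyl on the oxygen of the hydroxy group gives a number 24.4 percentage points lower from compound 2 to compound 4 (beyond the scatter), so an oxygen on the ring does not by itself hold the level of the hydroxy compound. Even so, methoxy in place of methyl on the aromatic carbon gives a number 10.6 percentage points higher from compound 1 to compound 4 (beyond the scatter), while 3-methoxyphenyl in place of 4-methylphenyl gives a number 8.4 percentage points higher from compound 3 to compound 4 (within the scatter), a step too small to read as a real change. Nothing here explains why these groups differ.

From the compounds shown here alone, how 3-aminophenyl or 4-hydroxyphenyl would behave on the amide-type nitrogen remains open.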